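The compounds below may be only part of what the source reports. "The series", "measured", "known", "first", "only" and "open" are said of these compounds alone.

Measured in a functional assay on HeLa cells (Homo sapiens) for cytotoxicity, read by neutral red uptake, with a stated time of 3 days; on this read-out higher numbers stand for weaker inhibition and lower numbers for stronger inhibition:
Compound 1 `Cc1c(F)c(N)c2c(=O)cc(-c3ccc(N)c(F)c3)oc2c1F`: > 100000 nM (a limit)
Compound 2 `[N-]=[N+]=Nc1c(F)c(N)c2c(=O)cc(-c3ccc(N)c(F)c3)oc2c1F`: 1200 nM

The value of compound 1 is a limit of this assay and not a number. Among the compounds with values here, that leaves compound 2, at 1200 nM, as the only true number in the set. Compound 2 can therefore be ranked against nothing but the limit of compound 1. Compound 3 `CN(C)c1c(F)c(N)c2c(=O)cc(-c3ccc(N)c(F)c3)oc2c1F` carries dimethylamino in place of azido on an aromatic carbon. Within the data shown here, the one measured step at this place is an at least 83-fold lower number from compound 1 to compound 2 (1.92 log units; beyond the scatter), large and beyond the scatter. From the compounds shown here alone, compound 3 gives up the azido group that came in with an at least 83-fold lower number from compound 1 to compound 2 (1.92 log units; beyond the scatter), so a higher number is expected in this assay, though dimethylamino itself is untested here. The expected size is a 17-fold higher number from compound 2 to compound 3 (1.22 log units; beyond the scatter), which is large but uncertain. For compound 3 the estimated value is 20000 nM, with an expected range of 3000 nM to 100000 nM.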

Compound 3, half-maximal inhibitory concentration: > 100000 nM
Compound 3 ended at the assay's limit; the forecaster's own chance of this, stated with the estimate: 35%; at least 5.0-fold (0.69 log units) between middle value and limit.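

In this assay, putting dimethylamino in place of azido on this aromatic carbon gives an at least 83-fold higher number from compound 2 to compound 3 (1.92 log units; beyond the scatter). Compound 3 gives > 100000 nM, which is a limit of this assay and not a number. Azido is now the only one of the three groups shown at this position that yields a true number, so its standing no longer rests on the comparison with methyl alone, and a second group with the same count of heavy atoms as azido also ends at the limit.

From the compounds shown here alone, the step between compound 1 and compound 3 cannot be read, and how these two compounds stand to each other stays open: the limit of > 100000 nM in this assay, at which 2 of the 3 values shown sit. Going by these compounds, whether a nitrile, a chloro group or a plain amine on this carbon would give a true number also remains open.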